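Reading compound 4 from a fluorine swap

The source may report more compounds than this note shows. Statements on the series, on what has been measured and on what is new or still open speak of the compounds shown alone.

- Compound 1 `CN(C)C(=O)c1cc2cnc(Nc3ccc(N)cn3)nc2n1C1CCCC1`: 68%
- Compound 2 `CN(C)C(=O)c1cc2cnc(Nc3ccc(NC(=O)C4(C(=O)Nc5cccc(F)c5)CC4)cc3)nc2n1C1CCCC1`: 85.6%
- Compound 3 `CN(C)C(=O)c1cc2cnc(Nc3ccc(NC(=O)C4(C(=O)Nc5ccccc5F)CC4)cc3)nc2n1C1CCCC1`: 82.6%

All three numbers come from a functional assay on OVCAR-5 cells (Homo sapiens) for inhibition, read by CCK-8 assay, with a stated time of 72 h, tested at 10 uM; a lower number here means less inhibition of growth, a higher number more inhibition of growth at the concentration tested. Compound 2 and compound 3 sit together at the top of this small set, within the scatter of each other. Compound 1 gives 68%, a number lower than that of compound 2 by more than the scatter.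

The next compound to consider is compound 4 `CN(C)C(=O)c1cc2cnc(Nc3ccc(NC(=O)C4(C(=O)Nc5ccc(Cl)c(C(F)(F)F)c5)CC4)cc3)nc2n1C1CCCC1`, which differs from compound 2 in one place: 4-chloro-3-(trifluoromethyl)phenyl in place of 3-fluorophenyl on an amide-type nitrogen. Put simply, 4-chloro-3-(trifluoromethyl)phenyl stands in place of 3-fluorophenyl on an amide-type nitrogen.

Going by the values given here, only one measured step touches this place: a number 3 percentage points lower from compound 2 to compound 3 (within the scatter). It exchanges one fluorophenyl group for another and shows no real change. Among the compounds with values here, that is limited guidance, since no measured compound carries a chlorine or a trifluoromethyl group, so the new group is untested here. The best expectation is therefore no step beyond the scatter in this assay, held with a wide margin.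

The expected change is a number 0.4 percentage points higher from compound 2 to compound 4 (within the scatter). For compound 4 the estimated value is 86%, with an expected range from 70% to 98%.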

Compound 4, percent growth inhibition at one concentration: 48%
The estimate for compound 4 lay 38 percentage points above the measured number, and the stated range ends above it.
By their numbers in this assay, from the lowest: compound 4; then compound 1; then compounds 3 and 2 (each within the scatter of the next).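

In this assay the aryl group on this amide-type nitrogen proves able to change the result greatly: placing 4-chloro-3-(trifluoromethyl)phenyl there gives a number 37.6 percentage points lower from compound 2 to compound 4 (beyond the scatter) and, set against the other fluorophenyl compound, a number 34.6 percentage points lower from compound 3 to compound 4 (beyond the scatter) as well. The earlier exchange of one fluorophenyl group for another gave only a number 3 percentage points lower from compound 2 to compound 3 (within the scatter) and so suggested a tolerant position, whereas these new steps show that this tolerance does not extend to every substituted phenyl group. No measurement offered here explains the loss of growth inhibition.

As far as these compounds go, the new group differs from both fluorophenyl groups by a chlorine and a trifluoromethyl group at once, so it remains open which of the two goes with the drop, or whether it takes both; the simpler 4-chlorophenyl and 3-(trifluoromethyl)phenyl groups would separate them. From the compounds shown here alone, it also remains open where an unsubstituted phenyl or a 4-methoxyphenyl group on this nitrogen would fall, and so whether the fluorophenyl compounds or compound 4 is the exception at this position.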